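The source may hold more compounds than are shown below. What is called first, only, known or untested is meant among the compounds shown, and "the series" means these compounds.

Measured compounds in a functional assay on KB cells (Homo sapiens) for cytotoxicity, read by MTT assay, with a stated time of 72 h; on this read-out lower numbers stand for stronger inhibition and higher numbers for weaker inhibition:
compound 1 `COc1cc2ncnc(NNC(=S)NC(=O)c3ccccc3Cl)c2cc1OC`: 3560 nM
compound 2 `COc1cc2ncnc(NNC(=S)NC(=O)c3ccccc3F)c2cc1OC`: 4070 nM
compound 3 `COc1ccccc1C(=O)NC(=S)NNc1ncnc2ccccc12`: > 50000 nM

Compound 3 returns only a limit in this assay, > 50000 nM, which is the limit of > 50000 nM in this assay, at which 1 of the 3 values shown sits. Going by the values given here, compound 1 and compound 2 give numbers, and the one measured step, a 1.1-fold higher number from compound 1 to compound 2 (0.06 log units; within the scatter), concerns a halogen swap on a different part of the series. Compound 4 `O=C(NC(=S)NNc1ncnc2ccccc12)c1ccccc1` differs from compound 3 by hydrogen in place of methoxy on an aromatic carbon. Among the compounds with values here, no measured step concerns a methoxy, and compound 3 itself has no number, so the size of the move cannot be set from the data; the working expectation is that compound 4 stays close to the limit. The step of an at least 1.1-fold lower number from compound 3 to compound 4 (0.04 log units; that floor lies within the scatter) is therefore expected to be small or absent. The estimate for compound 4 is 45000 nM, with a range of 12000 nM to 150000 nM.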

Compound 4, half-maximal inhibitory concentration: 2330 nM
For compound 4 the middle estimate is 19-fold (1.29 log units) above the measured one; the whole stated range lies above it.
By their numbers in this assay, from the lowest: compounds 4, 1 and 2 (each within the scatter of the next). At a limit, above all of these: compound 3.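

In this assay, the 2-methoxyphenyl to phenyl change, on an aromatic carbon ortho to a large group, gives a large step: an at least 21-fold lower number from compound 3 to compound 4 (1.33 log units; beyond the scatter). Compound 3 has only a limit, > 50000 nM, so that step is a floor. This position is therefore not indifferent to its substituent on this core, as hydrogen gives a measured number where methoxy gives only a limit.

Going by these compounds, the true size of the step stays open because compound 3 sits at a limit: the limit of > 50000 nM in this assay, at which 1 of the 4 values shown sits. Also open, on these data alone, is whether a hydroxyl or an amine in place of the methoxy would read nearer compound 4 or compound 3.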